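The source may report more compounds than this note shows. Statements on the series, on what has been measured and on what is new or still open speak of the compounds shown alone.

Measured in an in vitro ADME assay on microsomes from liver (Homo sapiens) for pharmacokinetics, read by LC-MS, with a stated time of 10 min, tested at 1 uM; on this read-out higher numbers stand for fast clearance and lower numbers for slow clearance:
- compound 1 `CN1C[C@H](C(=O)Nc2ccc(C(F)(F)F)cc2)[C@@H](c2ccc(/C=C/C(=O)Nc3ccccc3N)cc2)C1`: 6 mL/min/kg
- compound 2 `CN1C[C@H](C(=O)Nc2cccc(F)c2)[C@@H](c2ccc(/C=C/C(=O)Nc3ccccc3N)cc2)C1`: 6 mL/min/kg
- compound 3 `COc1cccc(NC(=O)[C@H]2CN(C)C[C@@H]2c2ccc(/C=C/C(=O)Nc3ccccc3N)cc2)c1`: 14 mL/min/kg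

Of these three, compound 3 stands highest, at 14 mL/min/kg. Compound 4 `CN1C[C@H](C(=O)Nc2ccccc2F)[C@@H](c2ccc(/C=C/C(=O)Nc3ccccc3N)cc2)C1` carries 2-fluorophenyl in place of 3-methoxyphenyl on an amide-type nitrogen.

The nearest evidence is a 2.3-fold higher number from compound 2 to compound 3 (0.37 log units; beyond the scatter), which came with methoxy in place of fluoro. A similar rise appears in a 2.3-fold higher number from compound 1 to compound 3 (0.37 log units; beyond the scatter), whereas no change at the digits printed from compound 1 to compound 2 (within the scatter) involved no methoxy group. Neither compound 1 nor compound 2 carries 2-fluorophenyl, so this reading is uncertain. A modest fall is therefore expected, with the estimated step being a 2.0-fold lower number from compound 3 to compound 4 (0.30 log units; within the scatter). The estimate for compound 4 is 7 mL/min/kg, with an expected range of 4 mL/min/kg to 13 mL/min/kg.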

Compound 4, clearance: 10 mL/min/kg
Compound 4: middle estimate off by 1.4-fold (0.15 log units), on the low side, within the range that was stated.
By their numbers in this assay, from the lowest: compounds 1, 2, 4 and 3 (each within the scatter of the next, the first and the last beyond it).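

Moving the fluorine, with 2-fluorophenyl in place of 3-fluorophenyl, gives a 1.7-fold higher number from compound 2 to compound 4 (0.22 log units; within the scatter) and so does not clearly shift clearance. Against the two groups that stood apart earlier, the change gives a 1.4-fold lower number from compound 3 to compound 4 (0.15 log units; within the scatter) for 3-methoxyphenyl and a 1.7-fold higher number from compound 1 to compound 4 (0.22 log units; within the scatter) for 4-(trifluoromethyl)phenyl. The new group therefore cannot be separated from any of the earlier ones, although compound 3 and compound 1 remain apart.

Nothing measured here explains these clearance numbers. On these data alone, whether a phenyl ring carrying an amine or a carboxylic acid on this nitrogen would move clearance beyond the scatter stays open.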